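A few compounds are considered here, and "the series" means these few. Any claim that something is new, unique, unknown or untested is made for them only; others in the source may bear on it.

Compound 1 `CCCn1c(Br)nc2c(N)nc(NCc3ccccc3)nc21` gives 1740 nM in a functional assay on CHO cells for antagonist activity at adenosine receptor A2b (Homo sapiens); a higher number here means a weaker inhibitor, a lower number a stronger inhibitor. Compound 2 `CCCn1c(Br)nc2c(N)nc(NCCCc3ccccc3)nc21` gives 6300 nM in this assay. The step of a 3.6-fold higher number from compound 1 to compound 2 (0.56 log units; beyond the scatter) leaves compound 2 with the higher of the two numbers. Compound 3 `CCCn1c(-c2ccco2)nc2c(N)nc(NCCCc3ccccc3)nc21` differs from compound 2 by furan-2-yl in place of bromo on an aromatic carbon. Among the measured compounds shown here, no measured step concerns this part of the core; the only step known changes the chain elsewhere, so it gives no direct guide. Compound 3 is therefore expected to stay near compound 2, with a 2.1-fold lower number from compound 2 to compound 3 (0.32 log units; beyond the scatter) small and uncertain in direction. Compound 3 is estimated at 3000 nM, within 600 nM to 15000 nM.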

Compound 3, inhibition constant: 8240 nM
For compound 3 the middle estimate is 2.7-fold (0.44 log units) below the measured one, and the stated range covers the measured number.
By their numbers in this assay, from the lowest: compound 1; then compounds 2 and 3 (each within the scatter of the next).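

In this assay, furan-2-yl in place of bromo on the aromatic carbon next to the ring atom that bears a propyl group gives a 1.3-fold higher number from compound 2 to compound 3 (0.12 log units; within the scatter). This position, which the earlier step did not touch, thus accepts a five-membered aromatic ring in place of a single bromine with no difference that can be told from the scatter. Nothing available explains this result. From the compounds shown here alone, whether an amine, a carboxylic acid or a longer alkyl chain on this carbon would change the number remains open. So does whether furan-2-yl would read the same with the chain of compound 1.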